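A few compounds are considered here, and "the series" means these few. Any claim that something is new, unique, unknown or untested is made for them only; others in the source may bear on it.

Compound 1, `COCCCN1C(/C=C/c2ccc(O)cc2)=CC(=O)CC1c1ccc(O)cc1`: 38800 nM
Compound 2, `COc1cc(/C=C/C(=O)/C=C(/C=C/c2ccc(O)c(OC)c2)NCCO)ccc1O`: 11800 nM

In a physicochemical assay for solubility, using the shake flask method, in phosphate buffer, with a stated time of 24 h, at pH 6.8 (on this read-out higher numbers stand for higher solubility and lower numbers for lower solubility), compound 1 gives 38800 nM, whereas compound 2 gives 11800 nM, the lower of the two numbers, and the gap between them lies beyond the scatter. Compound 3, `COCCCNC(=C\C(=O)/C=C/c1ccc(O)c(OC)c1)/C=C/c1ccc(O)c(OC)c1`, is still to be measured in this assay. It differs from compound 2 by methoxymethyl in place of hydroxy on a saturated chain carbon, two bonds along the chain from an amine nitrogen. For the measured compounds named here, no step between measured compounds is available for this kind of change, so the expectation rests on the structural change alone. A modest fall in solubility, at the edge of the scatter, is expected, so that the step from compound 2 to compound 3 is estimated as a 2.0-fold lower number from compound 2 to compound 3 (0.29 log units; within the scatter). Compound 3 is expected to give 6000 nM, within a range from 2000 nM to 18000 nM.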

Compound 3, solubility: 9660 nM
Compound 3: middle estimate off by 1.6-fold (0.21 log units), on the low side; the range from low to high includes it.
By their numbers in this assay, from the lowest: compounds 3 and 2 (each within the scatter of the next); then compound 1.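

In this assay, for the compounds shown here, putting methoxymethyl in place of hydroxy on a saturated chain carbon, two bonds along the chain from an amine nitrogen, gives a 1.2-fold lower number from compound 2 to compound 3 (0.09 log units; within the scatter) and provides the first step for this change. At this position, the hydroxy group and its hydrogen-bond donor can therefore give way to methoxymethyl without a step beyond the scatter. No measurement at hand bears on the cause of this result. The compounds shown leave open how an amine or a carboxylic acid at the end of this chain would read, and whether a longer chain would read the same.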